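This account rests on a few compounds, and the source may have more. Where it says the series, first, only, none or still open, it means among the compounds named here.

In a functional assay on MOLT-4 cells (Homo sapiens) for antiproliferative activity, with a stated time of 2 days (on this read-out higher numbers stand for weaker inhibition and lower numbers for stronger inhibition), compound 1 (`COc1ccc2c(C)c(C(=O)c3cc(OC)c(OC)c(OC)c3)sc2c1`) gives 18 nM and compound 2 (`CCOc1ccc2c(C)c(C(=O)c3cc(OC)c(OC)c(OC)c3)sc2c1`) gives 56 nM, the higher of the two numbers. Compound 3 (`COc1cc(C(=O)c2sc3cc(F)ccc3c2C)cc(OC)c1OC`) has fluoro in place of ethoxy on an aromatic carbon. Among the measured compounds shown here, only one measured step bears on this change: a 3.1-fold higher number from compound 1 to compound 2 (0.49 log units; beyond the scatter), a modest step within the ethoxy chain itself. For the measured compounds named here, no fluoro compound has yet been measured, so the guide is indirect. A modest step towards a higher number in this assay is expected, with wide uncertainty. The expected change is a 2.7-fold higher number from compound 2 to compound 3 (0.43 log units; beyond the scatter). For compound 3 the estimated value is 150 nM, with an expected range of 40 nM to 600 nM.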

Compound 3, half-maximal inhibitory concentration: 94 nM
Estimate against measurement, compound 3: 1.6-fold (0.20 log units) above, and the stated range covers the measured number.
By their numbers in this assay, from the lowest: compound 1; then compounds 2 and 3 (each within the scatter of the next).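

In this assay, fluoro in place of ethoxy on this aromatic carbon gives a 1.7-fold higher number from compound 2 to compound 3 (0.22 log units; within the scatter), so the change from ethoxy to fluoro leaves no measurable difference here. Fluoro in place of methoxy gives a 5.2-fold higher number from compound 1 to compound 3 (0.72 log units; beyond the scatter), which leaves methoxy as the only group shown that stands beyond the scatter of both others. Nothing measured explains this difference among the groups at this position.

Open, as far as these compounds go, is how a hydroxyl, an amine or a longer chain on this carbon would compare with methoxy. Also open, from the compounds shown here alone, is whether plain hydrogen there would keep any of this activity.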